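The source may hold more compounds than are shown below. What is called first, only, known or untested is meant among the compounds shown, and "the series" means these compounds.

Of the compounds shown here, three on a shared core have been tested in an ADME assay on THP-1 cells (Homo sapiens) for cytotoxicity, read by MTT assay, with a stated time of 72 h; on this read-out lower numbers stand for higher toxicity in this test and higher numbers for lower toxicity in this test. Compound 1 `c1ccc([C@@H]2C[C@@H]3Cc4ccc5ccccc5c4N2O3)cc1` carries a plain phenyl group; in this assay compound 1 gives > 350000 nM, which is a limit of the assay and not a number. Compound 2 `Fc1ccc([C@@H]2C[C@@H]3Cc4ccc5ccccc5c4N2O3)cc1` carries a 4-fluorophenyl group, and in this assay compound 2 gives > 300000 nM, again a limit. Compound 3 `COc1cccc([C@@H]2C[C@@H]3Cc4ccc5ccccc5c4N2O3)c1` carries a 3-methoxyphenyl group, and in this assay compound 3 gives > 300000 nM, also a limit. Compound 2 thus stands at a limit rather than at a measured number. The steps a step that the two limits leave unreadable from compound 1 to compound 2, a step that the two limits leave unreadable from compound 1 to compound 3 and a step that the two limits leave unreadable from compound 2 to compound 3 cannot be sized because the limit of > 300000 nM in this assay, at which 2 of the 3 values shown sit, and the limit of > 350000 nM in this assay, at which 1 of the 3 values shown sits, are both limits.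

Compound 4 `Cc1cccc([C@@H]2C[C@@H]3Cc4ccc5ccccc5c4N2O3)c1` differs from compound 2 by 3-methylphenyl in place of 4-fluorophenyl on a saturated ring carbon. Among the compounds with values here, the step that bears most on this change is the one from compound 2 to compound 3, an exchange of one aryl group for another on the same saturated ring carbon, and since it and the other two steps sit at the limits, no step beyond the scatter is expected in this assay. Compound 4 is expected to give 300000 nM, between 150000 nM and 1000000 nM, most likely once more as a limit. The estimated step is then a number no higher from compound 2 to compound 4 (the limit leaves the size open).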

Compound 4, half-maximal cytotoxic concentration: > 300000 nM
Compound 4: only a limit was reported; the forecaster's own chance of this, stated with the estimate: 85%; the middle value lies on the limit itself.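

In this assay compound 4 gives > 300000 nM, a limit and not a number. Within the data shown here, no step linking compound 4 with compound 1, compound 2 or compound 3 can be read. The compounds shown leave open at what concentration each becomes toxic to these cells, and whether their aryl groups make any difference.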